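The source may hold more compounds than are shown below. What is called first, only, known or untested is meant among the compounds shown, and "the series" means these compounds.

Working notes on the sulfonate series. All three measured members share the same core: compound 1 `CC(C)C(=O)Nc1cccc(S(=O)(=O)Oc2ccccc2C(C)C)c1`, compound 2 `CCC(=O)Nc1ccc(S(=O)(=O)Oc2ccccc2C(C)C)cc1` and compound 3 `CCC(=O)Nc1ccc(S(=O)(=O)Oc2ccccc2I)cc1`. In a functional assay on MCF7 cells (Homo sapiens) for antiproliferative activity, read by sulforhodamine B assay, with a stated time of 48 h (on this read-out higher numbers stand for weaker inhibition and lower numbers for stronger inhibition), compound 1 gives 13000 nM, compound 2 gives 11000 nM and compound 3 gives 8100 nM. Compound 3 holds the lowest of the three numbers, but its distance to compound 2 and to compound 1 is in both cases within the scatter, so no ordering among the three can be claimed. Among the compounds with values here, the only single-point step in the set is a 1.4-fold lower number from compound 2 to compound 3 (0.13 log units; within the scatter), a change at a different place and of no size beyond the scatter.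

The next member, compound 4 `O=C(Nc1ccc(S(=O)(=O)Oc2ccccc2I)cc1)NC1CC1`, arises from compound 3 by cyclopropylamino in place of ethyl on a carbonyl carbon, turning the propanoylamino group into a (cyclopropylcarbamoyl)amino group. Within the data shown here, no measured pair in the set changes the carbonyl substituent alone, so nothing in the data speaks directly to this step; the comparison of compound 1 with compound 2 mixes two changes and its two values lie within the scatter of each other. With all three measured numbers sitting in the same band, the expectation for the step is a number within the scatter of compound 3, that is a 1.0-fold lower number from compound 3 to compound 4 (0.01 log units; within the scatter). On that basis compound 4 is estimated at 8000 nM in this assay, with a range from 3000 nM to 25000 nM.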

Compound 4, half-maximal inhibitory concentration: 7400 nM
The estimate for compound 4 lay 1.1-fold (0.03 log units) above the measured number, within the range that was stated.
By their numbers in this assay, from the lowest: compounds 4, 3, 2 and 1 (each within the scatter of the next).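

Working notes on the carbonyl position. Within the data shown here, with the rest of compound 3 held fixed, cyclopropylamino in place of ethyl on a carbonyl carbon gives a 1.1-fold lower number from compound 3 to compound 4 (0.04 log units; within the scatter) in this assay and is the first single-point step at this place. The entering group carries a three-membered non-aromatic ring and a hydrogen-bond donor that ethyl lacks, yet propanoylamino and (cyclopropylcarbamoyl)amino cannot be told apart on this read-out, so in this one pair the exchange leaves the number inside the scatter. No supporting measurement bears on this result.

Still open is whether the carbonyl carbon stays this flat with a substituent of another kind, such as a longer alkyl chain, a carboxylic acid or an aminoethyl chain, all of which lie outside the compounds shown. Also open is whether the same exchange reads alike with isopropyl in place of iodo on the aromatic carbon, since the step is shown only for the iodo compounds.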